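Benzyl on the sulfur of compound 3: what to expect

The source may hold more compounds than are shown below. What is called first, only, known or untested is meant among the compounds shown, and "the series" means these compounds.

Going by the values given here, compound 3 `Sc1nnc(-c2ccccc2OCc2ccccc2)o1` is one of three compounds measured in a functional assay on the whole organism with Mus musculus as the target, in the maximal electroshock model; a higher number here means that more compound is needed for the effect, a lower number that less compound is needed. For compound 3 the result is a limit of the assay, not a number: >= 100 mg/kg. Compound 1 `Nc1nnc(-c2ccccc2OCc2ccc(F)cc2)o1` gives 3.3 mg/kg. Compound 2 `Nc1nnc(-c2ccccc2OCc2ccc(Cl)cc2)o1` gives only a limit of the assay, > 100 mg/kg. Among the compounds with values here, the one step measured between neighbours, an at least 30-fold higher number from compound 1 to compound 2 (1.48 log units; beyond the scatter), concerns a halogen on an aromatic ring and says nothing about the sulfur.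

Compound 4 `c1ccc(COc2ccccc2-c2nnc(SCc3ccccc3)o2)cc1` differs from compound 3 by benzyl in place of hydrogen on a sulfur. Within the data shown here, no measured step concerns a change at this sulfur, so no step size can be carried over; only the two limits the limit of > 100 mg/kg in this assay, at which 1 of the 3 values shown sits, and the limit of >= 100 mg/kg in this assay, at which 1 of the 3 values shown sits, show where the measured range ends. On this basis compound 4 is expected to stay near where compound 3 sits, with the step of an at least 1.2-fold lower number from compound 3 to compound 4 (0.09 log units; that floor lies within the scatter) meaning little movement. The estimate for compound 4 in this assay is 80 mg/kg, between 20 mg/kg and 300 mg/kg.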

Compound 4, dose for half-maximal effect: > 100 mg/kg
Compound 4 gave a limit, no number; the forecaster's own chance of this, stated with the estimate: 55%; at least 1.2-fold (0.09 log units) between middle value and limit.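

Going by these compounds alone, compound 3 and compound 4 both end at a limit of the assay, not at a number, so no step between them can be read in this assay. Left open is whether benzyl in place of hydrogen on the sulfur changes the dose needed at all, and in which direction.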